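The source may report more compounds than this note shows. Statements on the series, on what has been measured and on what is new or still open speak of the compounds shown alone.

In an ADME assay on HepG2 2.2.15 cells (Homo sapiens) for cytotoxicity (on this read-out higher numbers stand for lower toxicity in this test and lower numbers for higher toxicity in this test), three compounds that share one core have been measured. Compound 1 `O=C(OCCc1c(-c2ccccc2Cl)c2cc(Cl)ccc2[nH]c1=O)c1ccco1` gives 98000 nM, compound 2 `O=C(CCOc1ccccc1)OCCc1c(-c2ccccc2Cl)c2cc(Cl)ccc2[nH]c1=O` gives 46000 nM, and compound 3 `COc1ccccc1/C=C/C(=O)OCCc1c(-c2ccccc2Cl)c2cc(Cl)ccc2[nH]c1=O` gives 770000 nM, the highest of the three numbers. Compound 4 `COc1cccc(/C=C/C(=O)OCCc2c(-c3ccccc3Cl)c3cc(Cl)ccc3[nH]c2=O)c1` differs from compound 3 only in the methoxyphenyl group: 3-methoxyphenyl in place of 2-methoxyphenyl on a double-bonded chain carbon bound to a double-bonded chain carbon. Here, 3-methoxyphenyl replaces 2-methoxyphenyl on a double-bonded chain carbon bound to a double-bonded chain carbon.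

Within the data shown here, no measured pair shows this exact swap. The closest evidence comes from larger replacements on the carbonyl carbon, which gave a 2.1-fold lower number from compound 1 to compound 2 (0.33 log units; beyond the scatter), a 7.9-fold higher number from compound 1 to compound 3 (0.90 log units; beyond the scatter) and a 17-fold higher number from compound 2 to compound 3 (1.22 log units; beyond the scatter). These steps show that this side of the molecule can shift the number, but each one replaced a whole group. Moving a single methoxy group is a smaller edit, so a smaller step seems likely. With compound 3 at the top of the series at 770000 nM, a fall is the likelier direction, and the expected step is a 2.2-fold lower number from compound 3 to compound 4 (0.34 log units; beyond the scatter). Compound 4 is estimated at 350000 nM, with an expected range of 80000 nM to 1000000 nM.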

Compound 4, half-maximal cytotoxic concentration: > 1300000 nM
Compound 4 was reported as a limit; the forecaster's own chance of this, stated with the estimate: 15%; middle value at least 3.7-fold (0.56 log units) away from the limit.
By their numbers in this assay, from the lowest: compound 2; then compound 1; then compound 3. At a limit, above all of these: compound 4.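

Compound 4 is reported only as a limit in this assay: the limit of > 1300000 nM in this assay, at which 1 of the 4 values shown sits.

Putting 3-methoxyphenyl in place of 2-methoxyphenyl does not bring the number down, giving an at least 1.6-fold higher number from compound 3 to compound 4 (0.22 log units; that floor lies within the scatter), but this floor does not show that the methoxy move itself raises the number. The high numbers, which stand for lower toxicity in this test, now appear with the methoxy group in either place on the ethenyl chain, as 2-(3-methoxyphenyl)ethenyl gives an at least 28-fold higher number from compound 2 to compound 4 (1.45 log units; beyond the scatter) and an at least 13-fold higher number from compound 1 to compound 4 (1.12 log units; beyond the scatter).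

From the compounds shown here alone, it remains open whether the methoxy group is needed at all, since a plain phenyl on the same chain carbon would test that directly. A 3-hydroxyphenyl group there would show whether the oxygen alone is enough to keep the number this high.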